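A few compounds are considered here, and "the series" means these few. Any claim that something is new, unique, unknown or untested is made for them only; others in the source may bear on it.

Values in an assay on HEK293 cells for agonist activity at Toll-like receptor 8 (Homo sapiens), read by a luciferase reporter, with a stated time of 6 h (on this read-out lower numbers stand for an effect already at smaller amounts and higher numbers for an effect only at larger amounts of compound), for the measured compounds:
compound 1 `CCCCNc1nc(N)nc2c1CN(C(C)=O)CC2`: 0.5 uM
compound 2 `CCCCNc1nc(N)nc2c1CCN(C(C)=O)C2`: 0.4 uM
compound 3 `CCCCNc1nc(N)nc2c1CN(C(=O)c1ccccc1)CC2`: 1.4 uM

Compound 1 and compound 2 are built from the same atoms joined differently; the difference between the two cores is not broken down here. Their values in this assay lie within the usual scatter of each other, so neither can be placed ahead of the other.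

From compound 1 to compound 3 the change is phenyl in place of methyl on a carbonyl carbon. The step that it made: a 2.8-fold higher number from compound 1 to compound 3 (0.45 log units; beyond the scatter).

Compound 4 `CCCCNc1nc(N)nc2c1CCN(C(=O)c1ccccc1)C2` has not yet been measured in this assay. It differs from compound 2 by phenyl in place of methyl on a carbonyl carbon, the same change at the same place as from compound 1 to compound 3. Among the measured compounds shown here, from compound 2 to compound 4 a step of about the same size is expected, a 2.8-fold higher number from compound 2 to compound 4 (0.44 log units; beyond the scatter), because the one measured instance of this change gave a 2.8-fold higher number from compound 1 to compound 3 (0.45 log units; beyond the scatter). Compound 4 is therefore estimated at 1.1 uM, with a plausible range from 0.5 uM to 2.5 uM.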

Compound 4, minimum effective concentration: 0.8 uM
Compound 4: the middle estimate sits 1.4-fold (0.14 log units) above what was measured; the measured number falls inside the stated range.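

Phenyl in place of methyl on the carbonyl carbon gives a 2.0-fold higher number from compound 2 to compound 4 (0.30 log units; within the scatter) in this assay, so on this core the effect of the change cannot be told apart from the scatter of repeated measurements. Set beside the earlier step, it shows no difference between the two cores: the same change on two cores in this assay, a 2.8-fold higher number (0.45 log units; beyond the scatter) from compound 1 to compound 3 and a 2.0-fold higher number (0.30 log units; within the scatter) from compound 2 to compound 4, 1.4-fold (0.15 log units) apart, within the scatter of two such steps. This rests on one pair per core and one change, so it does not show that the two cores respond identically, as a small difference would stay hidden in the scatter, nor that other changes at this place would carry over.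

On these data alone, whether an amine or a longer chain on the carbonyl carbon, in place of methyl or phenyl, would behave alike on both cores stays open. As far as these compounds go, whether a substituted phenyl would follow the same step also stays open.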